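A few compounds are considered here, and "the series" means these few. Any claim that something is new, unique, unknown or untested is made for them only; others in the source may bear on it.

Measured so far:
compound 1 `CCOc1ccccc1C[C@@](O)(c1ccccc1)[C@@H]1CNCCO1` — 3.8%
compound 2 `O[C@](Cc1ccccc1SC(F)(F)F)(c1ccccc1)[C@@H]1CNCCO1` — 6.2%

In an assay on isolated protein for displacement of a labelled ligand from sodium-dependent dopamine transporter (Homo sapiens), tested at 1000 nM (a higher number here means more inhibition at the concentration tested (going by the name of the read-out), a lower number less inhibition), compound 1 gives 3.8% and compound 2 gives 6.2%. For the measured compounds named here, the one step between them, a number 2.4 percentage points higher from compound 1 to compound 2 (within the scatter), is within the scatter, so compound 2 stands at the higher of two numbers that cannot be told apart; the series so far shows no response to exchanging the group on that aromatic carbon.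

Compound 3 `O[C@](Cc1ccccc1Br)(c1ccccc1)[C@@H]1CNCCO1` is not yet measured. It differs from compound 2 by bromo in place of (trifluoromethyl)sulfanyl on an aromatic carbon, the site being an aromatic carbon of a six-membered aromatic ring of carbon only, ortho to a large group. Going by the values given here, the only step that bears on this position, a number 2.4 percentage points higher from compound 1 to compound 2 (within the scatter), was within the scatter, so no step beyond the scatter is expected in this assay in either direction. Compound 3 is therefore estimated at 6% (range 0% to 16%), an expected step of a number 0.2 percentage points lower from compound 2 to compound 3 (within the scatter).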

Compound 3, a percentage reported as inhibition, at one concentration (the size of the read-out at that concentration, not a potency): 24.1%
For compound 3 the middle estimate is 18.1 percentage points below the measured one; the whole stated range lies below it.
By their numbers in this assay, from the lowest: compounds 1 and 2 (each within the scatter of the next); then compound 3.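

In this assay this aromatic carbon proves sensitive to the group it carries, which the first pair could not show: there is a number 17.9 percentage points higher from compound 2 to compound 3 (beyond the scatter), and a number 20.3 percentage points higher from compound 1 to compound 3 (beyond the scatter). Bromo enters with 1 heavy atom and 0 hydrogen-bond acceptors where (trifluoromethyl)sulfanyl leaves with 5 heavy atoms and 1 hydrogen-bond acceptor, but these compounds cannot separate those differences from one another. No measurement in hand accounts for the rise.

As far as these compounds go, whether the rise is particular to bromo or extends to chloro, fluoro or methyl on the same carbon remains open. Also open, from the compounds shown here alone, is how an amine or a carboxylic acid at this position would read in this assay, and whether any group here would carry the number well beyond that of compound 3 at 24.1%.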